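Methyl for methoxy on compound 3

The source may report more compounds than this note shows. Statements on the series, on what has been measured and on what is new or still open speak of the compounds shown alone.

compound 1 (`COc1ccc(C=C(C(=O)c2cc(OC)c(OC)c(OC)c2)c2ccccc2)cc1F`) gives 790000 nM in a functional assay on K562 cells (Homo sapiens) for antiproliferative activity, read by MTT assay, with a stated time of 5 days; a lower number here means a stronger inhibitor, a higher number a weaker inhibitor
compound 2 (`COc1ccc(C=C(C(=O)c2cc(OC)c(OC)c(OC)c2)c2ccc(C)cc2)cc1`) gives 760000 nM in this assay
compound 3 (`COc1ccc(C(=Cc2ccc(OC)c(F)c2)C(=O)c2cc(OC)c(OC)c(OC)c2)cc1`) gives 450000 nM in this assay

Compound 3 (450000 nM) lies within the scatter of both compound 1 and compound 2. Compound 4 (`COc1ccc(C=C(C(=O)c2cc(OC)c(OC)c(OC)c2)c2ccc(C)cc2)cc1F`) differs from compound 3 by methyl in place of methoxy on an aromatic carbon, para to a large group (methyl in place of methoxy on an aromatic carbon). Among the measured compounds shown here, the one measured step on that carbon, hydrogen to methoxy, stayed small (a 1.8-fold lower number from compound 1 to compound 3 (0.24 log units; within the scatter)). Compound 2 (760000 nM) already carries the 4-methylphenyl group and also sits within the scatter of compound 3. No step beyond the scatter is therefore expected in this assay for this change. Compound 4 is expected at 600000 nM, with an estimated range from 300000 nM to 1100000 nM. That estimate means an expected step (a 1.3-fold higher number from compound 3 to compound 4 (0.12 log units; within the scatter)) within the scatter.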

Compound 4, half-maximal inhibitory concentration: 570000 nM
Compound 4: middle estimate off by 1.1-fold (0.02 log units), on the high side, within the range that was stated.
By their numbers in this assay, from the lowest: compounds 3, 4, 2 and 1 (each within the scatter of the next).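

On this aromatic carbon, para to a large group, methyl now stands alongside methoxy and hydrogen, and in this assay the exchange of methoxy for methyl gives a 1.3-fold higher number from compound 3 to compound 4 (0.10 log units; within the scatter). Methyl in place of hydrogen gives a 1.4-fold lower number from compound 1 to compound 4 (0.14 log units; within the scatter), so the three groups cannot be told apart here in this assay. Fluoro in place of hydrogen on an aromatic carbon, with the 4-methylphenyl group present, gives a 1.3-fold lower number from compound 2 to compound 4 (0.12 log units; within the scatter), and no measurement offers a cause for any of these steps. Still open, on these data alone, is whether an amine, a carboxylic acid or a longer chain on this carbon would give a step beyond the scatter.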